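One Ring Swap, Already Seen Once, Tried Again

This account rests on a few compounds, and the source may have more. Where it says the series, first, only, none or still open, it means among the compounds named here.

Of the compounds shown here, three have been measured in a functional assay on GLC82 cells (Homo sapiens) for cytotoxicity, read by MTT assay, with a stated time of 72 h; a higher number here means a weaker inhibitor, a lower number a stronger inhibitor. Compound 1 `COc1cc2ncnc(NNC(=S)NC(=O)c3ccccc3OC)c2cc1OC` gives 16000 nM in this assay. Compound 2 `COc1cc2ncnc(NNC(=S)NC(=O)c3ccc(F)cc3)c2cc1OC` gives 15300 nM in this assay. The change between them is 4-fluorophenyl in place of 2-methoxyphenyl on a carbonyl carbon and it produced a 1.0-fold lower number from compound 1 to compound 2 (0.02 log units; within the scatter). Compound 3 `COc1ccccc1C(=O)NC(=S)NNc1ncnc2ccccc12` gives 9500 nM in this assay; its value and those of compound 1 and compound 2 lie within the usual scatter of one another, so no order among the three can be read from these numbers. The difference between the core of compound 3 and the core of compound 1 is not broken down here.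

Compound 4 `O=C(NC(=S)NNc1ncnc2ccccc12)c1ccc(F)cc1` has not yet been measured. The change from compound 3 to compound 4 is 4-fluorophenyl in place of 2-methoxyphenyl on a carbonyl carbon, the same change as the one already seen, made at the same place on the other core. Because that earlier occurrence gave a 1.0-fold lower number from compound 1 to compound 2 (0.02 log units; within the scatter), the step now expected is a 1.1-fold lower number from compound 3 to compound 4 (0.02 log units; within the scatter), a step that stays within the scatter. For compound 4 the estimate in this assay is 9000 nM, with a likely range from 4500 nM to 18000 nM.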

Compound 4, half-maximal inhibitory concentration: 6070 nM
Compound 4: middle estimate off by 1.5-fold (0.17 log units), on the high side, within the range that was stated.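

In this assay, putting 4-fluorophenyl in place of 2-methoxyphenyl on the carbonyl carbon gives a 1.6-fold lower number from compound 3 to compound 4 (0.19 log units; within the scatter), so on this second core the change again stays within what repeated measurements would scatter by. Set side by side, the two occurrences of the change cannot be told apart: the same change on two cores in this assay, a 1.0-fold lower number (0.02 log units; within the scatter) from compound 1 to compound 2 and a 1.6-fold lower number (0.19 log units; within the scatter) from compound 3 to compound 4, 1.5-fold (0.18 log units) apart, within the scatter of two such steps. This shows that the two cores agree as far as these four compounds go, but it does not show that the change does nothing, since a small real effect could hide inside the scatter, and two pairs of compounds make no general rule for other cores.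

Going by these compounds, what stays open is whether any group on this carbonyl carbon moves the number beyond the scatter, for example a ring carrying an amine or a carboxylic acid, or a longer chain in place of the ring. On these data alone, whether such a group would act alike on both cores also remains unknown.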